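Swapping Chloro for Fluoro on an Aromatic Carbon

A few compounds are considered here, and "the series" means these few. Any claim that something is new, unique, unknown or untested is made for them only; others in the source may bear on it.

Measured so far:
Compound 1, `NC(=O)c1c(NC(=O)c2ccccc2Cl)sc2c1CCN(C(=S)Nc1cc(C(F)(F)F)cc(C(F)(F)F)c1)C2`: 15000 nM
Compound 2, `NC(=O)c1c(NC(=O)c2ccc(C(F)(F)F)cc2)sc2c1CCN(C(=S)Nc1ccccc1Cl)C2`: 16400 nM

Both compounds were tested in a functional assay on MKN-74 cells (Homo sapiens) for antiproliferative activity, with a stated time of 24 h; a lower number here means a stronger inhibitor, a higher number a weaker inhibitor. Compound 1 gives 15000 nM and compound 2 gives 16400 nM; the two numbers lie within the usual scatter of each other, so neither can be called the stronger inhibitor. Compound 1 has the lower number of the two, but only by a margin that carries no meaning here.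

Compound 3, `NC(=O)c1c(NC(=O)c2ccccc2F)sc2c1CCN(C(=S)Nc1cc(C(F)(F)F)cc(C(F)(F)F)c1)C2`, has not yet been measured. Its difference from compound 1 is this: fluoro in place of chloro on an aromatic carbon. One halogen is exchanged for another on the (2-chlorophenyl)carbonyl group, and the rest of the structure stays as it is. Within the data shown here, no pair of measured compounds shows this kind of change, so there is no measured step to lean on. A halogen swap of this size is expected to move the number little, if at all beyond the scatter, with no clear direction. For compound 3 in this assay the expected value is 18000 nM, with a range from 7000 nM to 45000 nM. The expected step is small: a 1.2-fold higher number from compound 1 to compound 3 (0.08 log units; within the scatter).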

Compound 3, half-maximal inhibitory concentration: 13300 nM
Compound 3: the middle estimate sits 1.4-fold (0.13 log units) above what was measured, within the range that was stated.
By their numbers in this assay, from the lowest: compounds 3, 1 and 2 (each within the scatter of the next).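

In this assay, fluoro in place of chloro on an aromatic carbon, ortho to a large group, gives a 1.1-fold lower number from compound 1 to compound 3 (0.05 log units; within the scatter). Among these compounds, this is the first comparison in which only this one atom differs. The structures of compound 1 and compound 2 differ in more than one place. The new pair shows that the 2-chlorophenyl and 2-fluorophenyl versions cannot be told apart in this read-out. There is no supporting measurement that would explain this outcome.

The pair covers only two halogens at a single position, so it cannot show whether this position matters in general; an amine, a methoxy group or a longer chain on the same carbon could still give a number beyond the scatter, or could fall within it as well. It also leaves open whether the same exchange would behave alike on the 2-chlorophenyl group of compound 2, which sits in a different part of the structure, and what would bring the numbers in this assay well below those of this series.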